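Swapping the Aniline Halogen on a Shared Core

The source may hold more compounds than are shown below. What is called first, only, known or untested is meant among the compounds shown, and "the series" means these compounds.

Measured so far:
- compound 1 `O=C(CSc1nc(Nc2ccccc2)c2ccccc2n1)Nc1ccccc1Cl`: 9610 nM
- compound 2 `C=CC(=O)Nc1cccc(NC(=O)CSc2nc(Nc3ccccc3F)c3ccccc3n2)c1`: 6580 nM

In a functional assay on NCI-H1975 cells (Homo sapiens) for inhibition, read by MTT assay, with a stated time of 72 h (on this read-out lower numbers stand for stronger inhibition and higher numbers for weaker inhibition), compound 1 gives 9610 nM and compound 2 gives 6580 nM. Compound 2 stands at the lower of the two numbers, yet its gap to compound 1 lies within the usual scatter, so the two compounds cannot be told apart on these data.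

Compound 3 `C=CC(=O)Nc1cccc(NC(=O)CSc2nc(Nc3ccc(Cl)cc3)c3ccccc3n2)c1` is not yet measured. It differs from compound 2 in one place: 4-chlorophenyl in place of 2-fluorophenyl on a nitrogen on an aromatic ring. Among the compounds with values here, no measured pair shows this change, so nothing here tells how the replacement of one halogen-bearing ring by another should move the number. The expectation is therefore a step no larger than the scatter, in either direction, a 1.2-fold lower number from compound 2 to compound 3 (0.08 log units; within the scatter). Compound 3 is estimated at 5500 nM in this assay, with a range from 1800 nM to 17000 nM.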

Compound 3, half-maximal inhibitory concentration: 7580 nM
Beside the measured number, compound 3's estimate is 1.4-fold (0.14 log units) below it, and the stated range covers the measured number.
By their numbers in this assay, from the lowest: compounds 2, 3 and 1 (each within the scatter of the next).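

In this assay, 4-chlorophenyl in place of 2-fluorophenyl on the nitrogen gives a 1.2-fold higher number from compound 2 to compound 3 (0.06 log units; within the scatter), a step within the scatter. Within the data shown here, this is the first measured pair that differs in one place, and it shows that this exchange of one halogen-bearing ring for another cannot be told apart from no change on this shared core. Nothing measured alongside these numbers bears on why the two rings read alike.

Going by these compounds, it remains open whether a different kind of group on this nitrogen, such as a phenyl ring carrying a methoxy group, a carboxylic acid or an amine, or a longer chain, would produce a step beyond the scatter. The effect of the rest of the molecule also remains unsettled, as compound 1 and compound 2 differ in more than one place.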